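Chlorophenyl Ureas on a Thienopyrimidine Core Against Colon Cells

The source may hold more compounds than are shown below. What is called first, only, known or untested is meant among the compounds shown, and "the series" means these compounds.

The account concerns four compounds carrying a urea linked to a chlorophenyl ring, tested in a functional assay on HT-29 cells (Homo sapiens) for cytotoxicity, read by MTT assay, with a stated time of 72 h; a lower number here means a stronger inhibitor, a higher number a weaker inhibitor. Compound 1 `CN(C)CCNc1nc(-c2ccc(NC(=O)Nc3ccc(Cl)cc3)cc2)nc2ccsc12` gives 95 nM in this assay. Compound 2 `CN(C)CCNc1nc(-c2ccc(NC(=O)Nc3ccccc3Cl)cc2)nc2ccsc12` differs from compound 1 by 2-chlorophenyl in place of 4-chlorophenyl on an amide-type nitrogen, and in this assay compound 2 gives 310 nM; the change produced a 3.3-fold higher number from compound 1 to compound 2 (0.51 log units; beyond the scatter). Compound 3 `CCN(CC)CCCNc1nc(-c2ccc(NC(=O)Nc3ccc(Cl)cc3)cc2)nc2c(Cl)c(Cl)sc12` has a different core from compound 1, and the difference between the two cores is not broken down here. In this assay compound 3 gives 250 nM, a number close to that of compound 2 and higher than that of compound 1.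

Compound 4 `CCN(CC)CCCNc1nc(-c2ccc(NC(=O)Nc3ccccc3Cl)cc2)nc2c(Cl)c(Cl)sc12` has not yet been measured. It differs from compound 3 by 2-chlorophenyl in place of 4-chlorophenyl on an amide-type nitrogen, at a place described in the same words as for the step from compound 1 to compound 2, so this is the same change made on the core of compound 3. Among the compounds with values here, the only reference for this change is the step from compound 1 to compound 2, and on that basis compound 4 is expected to show a higher number than compound 3 by about the same margin, which is a 3.2-fold higher number from compound 3 to compound 4 (0.51 log units; beyond the scatter). Because compound 3 already gives 250 nM, the estimate for compound 4 in this assay is 800 nM, with a range from 350 nM to 2000 nM.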

Compound 4, half-maximal inhibitory concentration: 410 nM
The estimate for compound 4 lay 2.0-fold (0.29 log units) above the measured number, and the stated range covers the measured number.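

In this assay, the exchange of 4-chlorophenyl for 2-chlorophenyl on an amide-type nitrogen gives a 1.6-fold higher number from compound 3 to compound 4 (0.21 log units; within the scatter), so on the core of compound 3 the step alone does not rise above the noise of the measurement. Set beside the same exchange on the core of compound 1, the two steps cannot be told apart: the same change on two cores in this assay, a 3.3-fold higher number (0.51 log units; beyond the scatter) from compound 1 to compound 2 and a 1.6-fold higher number (0.21 log units; within the scatter) from compound 3 to compound 4, 2.0-fold (0.30 log units) apart, within the scatter of two such steps This shows that the result is compatible with the change carrying over from one core to the other, but it does not show that the step has the same size on both cores, nor that the cores alter it, and two pairs in a single assay set no rule for the series.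

The compounds shown leave open how the same nitrogen would respond to a plain phenyl, a fluorophenyl or a methoxyphenyl group in place of either chlorophenyl group. On these data alone, they also do not separate the parts of the difference between the two cores, so it remains unknown whether the step would hold on a core carrying only the diethylamino chain, or only the two ring chlorines, or a morpholine in place of either terminal amine.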